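Swapping Phenyl for Ethyl on the Shared Core

This account rests on a few compounds, and the source may have more. Where it says the series, first, only, none or still open, it means among the compounds named here.

Measured compounds:
compound 1 `Cc1ccc(NC(=O)Nn2c(-c3ccccc3)nc3ccccc3c2=O)cc1` — 54%
compound 2 `O=C(Nc1ccc(F)cc1)Nn1c(-c2ccccc2)nc2ccccc2c1=O` — 54%

In a functional assay on the whole organism (strain albino) with Mus musculus as the target, at a dose of 100 mg/kg by the intraperitoneal route (a lower number here means less inhibition, a higher number more inhibition at the dose given (going by the name of the read-out)), compound 1 gives 54%. Compound 2 differs from it by a fluoro in place of methyl on an aromatic carbon, and the step of no change at the digits printed from compound 1 to compound 2 (within the scatter) shows that this swap left the read-out unchanged within the scatter. For the measured compounds named here, compound 1 therefore stands level with compound 2, its only measured neighbour, and neither number is higher or lower than the other.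

Compound 3 `CCc1nc2ccccc2c(=O)n1NC(=O)Nc1ccc(C)cc1` has not yet been measured in this assay. It differs from compound 1 in the following way: ethyl in place of phenyl on an aromatic carbon. Going by the values given here, the one measured step touches a different part of the molecule, the group on the outer aromatic ring, and was within the scatter; no measured step speaks to the place where the phenyl sits on the shared core. There is thus no evidence for a directional shift, but also no evidence that a change at this position leaves the number level. Compound 3 is expected to give about 45%, within a range of 20% to 70%, which would mean a step of a number 9 percentage points lower from compound 1 to compound 3 (within the scatter).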

Compound 3, a percentage reported as inhibition, in the whole organism at one dose (the size of the read-out at that dose, not a potency): 55%
Compound 3: middle estimate off by 10 percentage points, on the low side; the measured number falls inside the stated range.
By their numbers in this assay, from the lowest: compounds 1, 2 and 3 (each within the scatter of the next).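

In this assay, the change at the aromatic carbon between two ring nitrogen atoms of the shared core, ethyl in place of phenyl, gives a number 1 percentage points higher from compound 1 to compound 3 (within the scatter). For the compounds shown here, this is the first measured step at this position, and it shows that the read-out at this dose can stay level when a six-membered aromatic ring of 6 heavy atoms gives way to a chain of 2 heavy atoms, so in this pair the phenyl ring is not needed to hold the number. Nothing available explains why the value holds across this swap.

The compounds shown leave open whether the position accepts any group or only some, for instance whether a longer chain such as butyl, or an amine, on the same carbon would also leave the read-out level. Each number also describes the size of the effect at one dose and is not a potency, so the matching values of compound 1 and compound 3 do not settle whether the two would still match at other doses.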